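Amine chain variation on the shared core

This account rests on a few compounds, and the source may have more. Where it says the series, first, only, none or still open, it means among the compounds named here.

In a functional assay on HEK293 cells for agonist activity at Toll-like receptor 8 (Homo sapiens), read by reporter gene assay (on this read-out higher numbers stand for an effect only at larger amounts of compound and lower numbers for an effect already at smaller amounts), compound 1 `CCCCCNc1oc2c(C)ncc(CO)c2c1Nc1ccccn1` gives 5810 nM. Within the data shown here, compound 2 `CCCC(C)Nc1oc2c(C)ncc(CO)c2c1Nc1ccccn1` gives 9010 nM in this assay; this is the highest of the two numbers so far, and the step of a 1.6-fold higher number from compound 1 to compound 2 (0.19 log units; within the scatter) stays within the scatter. Compound 3 `Cc1ncc(CO)c2c(Nc3ccccn3)c(NC(C)C)oc12` is not yet measured. It differs from compound 2 by hydrogen in place of ethyl on a saturated chain carbon, two bonds along the chain from a nitrogen on an aromatic ring, so 1-methylbutyl becomes isopropyl. Among the measured compounds shown here, the only measured step, a 1.6-fold higher number from compound 1 to compound 2 (0.19 log units; within the scatter), rearranged the chain without shortening it; no measured step removes carbon from this chain. For compound 3 no movement beyond the scatter in this assay is therefore expected, the expected step being a 1.1-fold higher number from compound 2 to compound 3 (0.05 log units; within the scatter). Compound 3 is estimated at 10000 nM, with a wide range from 3000 nM to 35000 nM given the lack of a directly comparable step.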

Compound 3, half-maximal effective concentration: "not active" (no number reported)
No number was reported for compound 3; there is nothing to compare the estimate with.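

Among these compounds, compound 3 is reported as not active in this assay, without a number, so no step from compound 2 to compound 3 can be read. The compounds shown leave open how far activity on this read-out tolerates isopropyl in place of 1-methylbutyl. No supporting data bear on this result.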